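The source may hold more compounds than are shown below. What is called first, only, known or untested is meant among the compounds shown, and "the series" means these compounds.

Measured in an ADME assay on KB cells (Homo sapiens) for cytotoxicity, read by MTT assay, with a stated time of 72 h; on this read-out lower numbers stand for stronger inhibition and higher numbers for weaker inhibition:
- compound 1 `COc1ccc(C2=C(c3cc(OC)c(OC)c(OC)c3)C(=O)C(OC(C)=O)C2)cc1F`: 33 ug/mL
- compound 3 `COc1ccc(C2=C(c3cc(OC)c(OC)c(OC)c3)C(=O)C(OC(C)=O)C2)cc1Cl`: 64 ug/mL
- compound 2 `COc1ccc(C2=C(c3cc(OC)c(OC)c(OC)c3)C(=O)CC2O[SiH2]C(C)(C)C)cc1OC`: > 100 ug/mL, a limit of the assay rather than a number

Compound 2 therefore stands at the limit of > 100 ug/mL in this assay, at which 1 of the 3 values shown sits, and no number is known for it. Compound 4 `COc1ccc(OC)c(C2=C(c3cc(OC)c(OC)c(OC)c3)C(=O)CC2O[SiH2]C(C)(C)C)c1` keeps the same atoms but differs in one place: 2,5-dimethoxyphenyl in place of 3,4-dimethoxyphenyl on a double-bonded ring carbon. Among the measured compounds shown here, the only step measured between compounds that differ in one place is a 1.9-fold higher number from compound 1 to compound 3 (0.29 log units; within the scatter), a change on an aromatic ring that stayed within the scatter; it does not touch the silyl ether or the dimethoxyphenyl ring. With nothing pointing to a shift, compound 4 is expected to remain near the limit. Compound 4 is estimated at 100 ug/mL, between 40 ug/mL and 300 ug/mL. This estimate means an expected step of a number no higher from compound 2 to compound 4 (the limit leaves the size open).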

Compound 4, half-maximal inhibitory concentration: 10 ug/mL
Estimate against measurement, compound 4: 10-fold (1.00 log units) above; the whole stated range lies above it.
By their numbers in this assay, from the lowest: compound 4; then compounds 1 and 3 (each within the scatter of the next). At a limit, above all of these: compound 2.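

On a double-bonded ring carbon of the five-membered ring, 2,5-dimethoxyphenyl in place of 3,4-dimethoxyphenyl gives an at least 10-fold lower number from compound 2 to compound 4 (1.00 log units; beyond the scatter), although the atoms stay the same. Among the compounds shown here, the only earlier step stayed within the scatter, so this is the first sign that the ring at this place can change the read-out, here simply by how its two methoxy groups are arranged. The full size of the step stays unknown because compound 2 sits at a limit: the limit of > 100 ug/mL in this assay, at which 1 of the 4 values shown sits.

The compounds shown leave open whether 2,5-dimethoxyphenyl would act the same way on the core of compound 1. They also leave open what an amine or a carboxylic acid on this ring would do.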